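Second ethyl on the aniline ring of compound 1

The source may hold more compounds than are shown below. What is called first, only, known or untested is meant among the compounds shown, and "the series" means these compounds.

Compound 1, `CCc1ccccc1NC(=O)N[C@H](C)c1ccccc1`, is the reference point. In an ADME assay on the whole organism with Oryza sativa as the target, tested at 10 uM (on this read-out lower numbers stand for a stronger effect and higher numbers for a weaker effect at the one concentration tested), compound 1 gives 92%. Its two measured partners carry a halogen instead of the ethyl group on the same aromatic carbon: compound 2, `C[C@@H](NC(=O)Nc1ccccc1Cl)c1ccccc1`, gives 93% and compound 3, `C[C@@H](NC(=O)Nc1ccccc1Br)c1ccccc1`, gives 94%. The three numbers sit together, with a number 1 percentage points higher from compound 1 to compound 2 (within the scatter), a number 2 percentage points higher from compound 1 to compound 3 (within the scatter) and a number 1 percentage points higher from compound 2 to compound 3 (within the scatter); none of these moves is beyond the scatter, so compound 1 cannot be separated from the other two on the numbers shown.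

Compound 4, `CCc1cccc(CC)c1NC(=O)N[C@H](C)c1ccccc1`, differs from compound 1 by ethyl in place of hydrogen on an aromatic carbon. Going by the values given here, no measured step adds a group to a hydrogen on this ring; the steps that do exist only swap one group for another at the aromatic carbon already substituted, and all stayed within the scatter. The second ethyl group enters on an aromatic carbon of the six-membered aromatic ring of carbon only, ortho to a large group and meta to an ethyl group.

With every measured step flat, the expectation for compound 4 is no step beyond the scatter, a number 1 percentage points higher from compound 1 to compound 4 (within the scatter). Compound 4 is therefore estimated at 93%, within 84% to 100%.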

Compound 4, a percentage reported as activity, at one concentration (the size of the read-out at that concentration, not a potency): 99%
Estimate against measurement, compound 4: 6 percentage points below; the measured number falls inside the stated range.
By their numbers in this assay, from the lowest: compounds 1, 2, 3 and 4 (each within the scatter of the next).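

Ethyl in place of hydrogen on an aromatic carbon, ortho to a large group and meta to an ethyl group, is the first change in this set that adds a group at a ring hydrogen rather than swapping one group for another, and in this assay it gives a number 7 percentage points higher from compound 1 to compound 4 (within the scatter). This position of the six-membered aromatic ring of carbon only therefore takes a second ethyl without a step beyond the scatter, which matches the flat swaps at the aromatic carbon already substituted but extends that picture to a new place on the ring. No measurement shown here offers an explanation for this result.

Going by these compounds, whether this position stays equally flat with a group of a different kind, such as an amine, a carboxylic acid or a longer chain, remains open. All four compounds also lie within the scatter of their neighbours in this assay at a single concentration, and they leave open which change to the core of compound 1 could produce a step beyond the scatter.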